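The source may hold more compounds than are shown below. What is called first, only, known or untested is meant among the compounds shown, and "the series" means these compounds.

Measured so far in a functional assay on SMMC-7721 cells (Homo sapiens) for cytotoxicity, read by MTT assay, with a stated time of 24 h; a lower number here means a stronger inhibitor, a higher number a weaker inhibitor:
- compound 1 `O=C1/C(=C/c2ccccc2F)CN(S(=O)(=O)c2ccc(F)cc2)C/C1=C\c1ccccc1F` gives 7700 nM
- compound 2 `O=C1/C(=C/c2ccccc2F)CN(S(=O)(=O)c2ccc(Cl)cc2)C/C1=C\c1ccccc1F` gives 4500 nM
- compound 3 `O=C1/C(=C/c2cccc(F)c2)CN(S(=O)(=O)c2ccc(F)cc2)C/C1=C\c1cccc(F)c1` gives 13500 nM

Compound 1 and compound 2 share one core and differ only in chloro in place of fluoro on an aromatic carbon; this change gave a 1.7-fold lower number from compound 1 to compound 2 (0.23 log units; within the scatter). Compound 3 carries a different core; the difference between the two cores is not broken down here, and the numbers for compound 3 and compound 1 lie within the scatter of each other.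

Compound 4 `O=C1/C(=C/c2cccc(F)c2)CN(S(=O)(=O)c2ccc(Cl)cc2)C/C1=C\c1cccc(F)c1` is not yet measured. It arises from compound 3 by chloro in place of fluoro on an aromatic carbon, the same change at the same kind of place as that from compound 1 to compound 2. The step in this assay is expected to be of like size, a 1.7-fold lower number from compound 3 to compound 4 (0.23 log units; within the scatter), because the earlier instance gave a 1.7-fold lower number from compound 1 to compound 2 (0.23 log units; within the scatter). Compound 4 is therefore estimated at 8000 nM, with a range from 4500 nM to 14000 nM.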

Compound 4, half-maximal inhibitory concentration: 7800 nM
Compound 4: middle estimate off by 1.0-fold (0.01 log units), on the high side; the range from low to high includes it.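

In this assay, chloro in place of fluoro on an aromatic carbon gave a 1.7-fold lower number from compound 3 to compound 4 (0.24 log units; within the scatter), and the step carried from one core to the other with no difference between its two instances: the same change on two cores in this assay, a 1.7-fold lower number (0.23 log units; within the scatter) from compound 1 to compound 2 and a 1.7-fold lower number (0.24 log units; within the scatter) from compound 3 to compound 4, 1.0-fold (0.00 log units) apart, within the scatter of two such steps. Each step lies within the scatter, which makes this agreement between two small steps and does not establish a real gain from chloro on either core. Two cores and one pair of halogens also cannot show that the step would hold on any further core.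

Still open, going by these compounds, is how other groups in this place, such as a methoxy group, an amine or a carboxylic acid, would compare with 4-fluorophenyl and 4-chlorophenyl. Also open, on these data alone, is whether a larger step exists at this position.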